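The compounds below may be only part of what the source reports. "The series", "measured", "known", "first", "only" and "open" are said of these compounds alone.

Measured so far in a functional assay on MV4-11 cells (Homo sapiens) for inhibition, read by luminescence and CellTiter-Glo, with a stated time of 72 h; on this read-out lower numbers stand for stronger inhibition and higher numbers for weaker inhibition:

Compound 1, `CCN1CCN(c2c(C(C)=O)c(=O)oc3cc(Nc4ncc(F)c(-c5ccc(F)cc5OC)n4)ccc23)CC1`, gives 550 nM.
Compound 2, `COc1cc(F)ccc1-c1nc(Nc2ccc3c(N4CCCNCC4)c(C(C)=O)c(=O)oc3c2)ncc1F`, gives 420 nM.
Compound 3, `COc1cc(F)ccc1-c1ccnc(Nc2ccc3c(N4CCN(C)CC4)c(C(C)=O)c(=O)oc3c2)n1`, gives 520 nM.

In this assay compound 3 stands close to both of its neighbours: its number is within the scatter of compound 1 and of compound 2, so the three measured compounds cannot be told apart on this read-out. Compound 4, `COc1cc(F)ccc1-c1nc(Nc2ccc3c(N4CCN(C)CC4)c(C(C)=O)c(=O)oc3c2)ncc1F`, differs from compound 3 in one place: fluoro in place of hydrogen on an aromatic carbon. Going by the values given here, the only single-point step among the measured compounds, a 1.3-fold lower number from compound 1 to compound 2 (0.12 log units; within the scatter), concerns the amine on the shared core and not this position, so no measured step bears directly on the change from compound 3 to compound 4. Compound 1 and compound 2 both carry the fluoro and give numbers within the scatter of compound 3, which lacks it; this observation alone suggests the fluoro makes little difference here. Compound 4 is therefore expected to show a 1.2-fold lower number from compound 3 to compound 4 (0.06 log units; within the scatter), that is no step beyond the scatter. The estimate for compound 4 in this assay is 450 nM, expected to fall between 200 nM and 1100 nM.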

Compound 4, half-maximal inhibitory concentration: 400 nM
Estimate against measurement, compound 4: 1.1-fold (0.05 log units) above; the range from low to high includes it.
By their numbers in this assay, from the lowest: compounds 4, 2, 3 and 1 (each within the scatter of the next).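

In this assay, the fluoro in place of hydrogen, ortho to the 4-fluoro-2-methoxyphenyl group, can now be read directly: it gives a 1.3-fold lower number from compound 3 to compound 4 (0.11 log units; within the scatter), so on this read-out the change cannot be told from no change at this position. With the fluoro held in place, the amine steps behave alike, with a 1.1-fold lower number from compound 2 to compound 4 (0.02 log units; within the scatter) for 4-methylpiperazin-1-yl in place of 1,4-diazepan-1-yl and a 1.4-fold lower number from compound 1 to compound 4 (0.14 log units; within the scatter) for 4-methylpiperazin-1-yl in place of 4-ethylpiperazin-1-yl. No measurement is available here that would account for these results.

As far as these compounds go, whether a chloro, a nitrile or a methoxy group at this position would give a step beyond the scatter remains open. The same holds for a morpholine, or a piperazine bearing a carboxylic acid, on the shared core.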